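The source may hold more compounds than are shown below. What is called first, only, known or untested is meant among the compounds shown, and "the series" means these compounds.

Measured so far:
compound 1, `O=C(/C=C/C(=O)N1C/C(=C\c2ccc([N+](=O)[O-])cc2)C(=O)/C(=C/c2ccc([N+](=O)[O-])cc2)C1)Nc1ccc(Cl)c(Cl)c1`: 600 nM
compound 2, `COc1ccc(NC(=O)/C=C/C(=O)N2C/C(=C\c3ccccc3)C(=O)/C(=C/c3ccccc3)C2)cc1`: 1100 nM

In a functional assay on Molt4/C8 cells (Homo sapiens) for cytotoxicity (a higher number here means a weaker inhibitor, a lower number a stronger inhibitor), compound 1 gives 600 nM, the lower of the two numbers shown, while compound 2 gives 1100 nM; the gap between them is within the usual scatter, so no order between the two is claimed. Both share the same core, differing in the groups on the two exocyclic double bonds and on the amide-type nitrogen.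

Compound 3, `O=C(/C=C/C(=O)N1C/C(=C\c2ccc([N+](=O)[O-])cc2)C(=O)/C(=C/c2ccc([N+](=O)[O-])cc2)C1)Nc1ccccc1`, is not yet measured. phenyl in place of 3,4-dichlorophenyl on an amide-type nitrogen Here 3,4-dichlorophenyl leaves and phenyl enters. Within the data shown here, no measured pair differs in one place, so the size of this step is not fixed by the data. The expectation is a modest weakening, a step from compound 1 to compound 3 of about a 1.7-fold higher number from compound 1 to compound 3 (0.22 log units; within the scatter), at the edge of the scatter. For compound 3 the value in this assay is estimated at 1000 nM, with a range of 400 nM to 2500 nM.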

Compound 3, half-maximal inhibitory concentration: 360 nM
Compound 3: the middle estimate sits 2.8-fold (0.44 log units) above what was measured; measured number outside the range, below it.
By their numbers in this assay, from the lowest: compounds 3, 1 and 2 (each within the scatter of the next, the first and the last beyond it).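

Phenyl in place of 3,4-dichlorophenyl on the amide-type nitrogen gives the first one-place step in the series. In this assay it reads a 1.7-fold lower number from compound 1 to compound 3 (0.22 log units; within the scatter) and so cannot be told apart from repeat scatter. At this position, then, the aryl group can lose both chlorine atoms with no change that this assay can resolve. No supporting data on hand bear on this result.

No pair among the compounds shown isolates the nitro groups on the exocyclic double bonds, so their contribution stays unread, and it is open whether this step would read the same with another group there. Also open, as far as these compounds go, is how this position responds to a group of a different kind on the amide-type nitrogen, such as a carboxylic acid or amine on the phenyl, or a longer alkyl chain in its place.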